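Lengthening the chain on compound 3

A few compounds are considered here, and "the series" means these few. Any claim that something is new, unique, unknown or untested is made for them only; others in the source may bear on it.

Measured in a functional assay on A549 cells (Homo sapiens) for antiproliferative activity, read by MTT assay, with a stated time of 48 h; on this read-out higher numbers stand for weaker inhibition and lower numbers for stronger inhibition:
- compound 1 `CCC/C=C1/C(=O)Nc2ccc(Nc3ccc(C)cc3)cc21` gives 3600 nM
- compound 2 `CC(C)CCC1C(=O)Nc2ccc(Nc3ccc(Cl)cc3)cc21` gives 2000 nM
- compound 3 `CCCCC1(O)C(=O)Nc2ccc(Nc3ccc(C)cc3)cc21` gives 7500 nM

Compound 3 has the highest number of the three, so it is the weakest inhibitor so far. Its value lies beyond the scatter from both others, with compound 1 nearest and compound 2 furthest.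

The next compound is compound 4 `CCCCCCC1(O)C(=O)Nc2ccc(Nc3ccc(C)cc3)cc21`. It carries ethyl in place of hydrogen on a saturated chain carbon, four bonds along the chain from a saturated ring carbon.

Within the data shown here, no measured pair isolates a change of this kind, so the data give no direct guide to its size. All three values in this assay sit in a narrow span, from compound 2 at 2000 nM to compound 3 at 7500 nM, so a large move is not expected. A modest shift toward a lower number, close to the scatter, is expected, and the estimated step is a 1.5-fold lower number from compound 3 to compound 4 (0.18 log units; within the scatter).

For compound 4 the estimated value is 5000 nM, with an expected range of 2000 nM to 12000 nM.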

Compound 4, half-maximal inhibitory concentration: 12100 nM
Compound 4: the middle estimate sits 2.4-fold (0.38 log units) below what was measured; measured number outside the range, above it.
By their numbers in this assay, from the lowest: compounds 2 and 1 (each within the scatter of the next); then compounds 3 and 4 (each within the scatter of the next).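

In this assay, ethyl in place of hydrogen on a saturated chain carbon, four bonds along the chain from a saturated ring carbon, gives a 1.6-fold higher number from compound 3 to compound 4 (0.21 log units; within the scatter). Among these compounds, this is the first step that isolates a change in one place, and it shows that this position takes the added ethyl without a difference that can be separated from the usual scatter of the read-out. No supporting measurement bears on the size of this step.

On these data alone, whether a longer chain at the same position would stay within the scatter remains open, as does the outcome of ending the chain in an amine or a carboxylic acid. A single step also leaves open whether the same ethyl would behave alike on the core of compound 2.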